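Methyl to carboxy: working notes on a small series

The source may hold more compounds than are shown below. What is called first, only, known or untested is meant among the compounds shown, and "the series" means these compounds.

Three compounds sharing one core have numbers in a functional assay on MCF7 cells (Homo sapiens) for cytotoxicity, read by sulforhodamine B assay, with a stated time of 24 h; a lower number here means a stronger inhibitor, a higher number a weaker inhibitor. Compound 1 (`N=c1oc2ccccc2cc1C(=O)N/N=C1\C(=O)Nc2ccc(S(=O)(=O)N3CCOCC3)cc21`) gives 20800 nM, compound 2 (`Cc1ccc(/N=C2\C(=O)Nc3ccc(S(=O)(=O)N4CCOCC4)cc32)cc1`) gives 55900 nM, and compound 3 (`COc1ccc(-c2c(C#N)c(N)n(/N=C3\C(=O)Nc4ccc(S(=O)(=O)N5CCOCC5)cc43)c(=O)c2C#N)cc1`) gives 33400 nM. Compound 2 sits at the upper end of these numbers. It is level with compound 3 within the scatter, while compound 1 lies lower, beyond the scatter.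

Compound 4 (`O=C1Nc2ccc(S(=O)(=O)N3CCOCC3)cc2/C1=N/c1ccc(C(=O)O)cc1`) has not yet been measured. It keeps the core of compound 2 and differs in one place, 4-methylphenyl to 4-carboxyphenyl, with carboxy in place of methyl on an aromatic carbon, para to a large group: carboxy in place of methyl on an aromatic carbon.

Among the measured compounds shown here, no pair of measured compounds differs in one place only, so the data do not show directly what this change does. For the measured compounds named here, the only guide is the spread of the series, which runs from compound 1 at 20800 nM to compound 2 at 55900 nM despite quite different groups on the shared core. The step of a 1.2-fold lower number from compound 2 to compound 4 (0.09 log units; within the scatter) is therefore expected to stay within the scatter, with no firm direction and at most a slight drift towards the middle of that spread. For compound 4 the estimated value is 45000 nM, with an expected range of 17000 nM to 110000 nM.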

Compound 4, half-maximal inhibitory concentration: 26700 nM
Beside the measured number, compound 4's estimate is 1.7-fold (0.23 log units) above it, within the range that was stated.
By their numbers in this assay, from the lowest: compounds 1, 4, 3 and 2 (each within the scatter of the next, the first and the last beyond it).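

Notes on the 4-methylphenyl to 4-carboxyphenyl change

In this assay, this change gives the series its first comparison of compounds that differ in one place only, and the step is a 2.1-fold lower number from compound 2 to compound 4 (0.32 log units; beyond the scatter). The number at this position, on an aromatic carbon para to a large group, therefore responds to the substituent, though only modestly, and the carboxy group with its hydrogen-bond donor and acceptor is accepted here without a rise in the number. Nothing at hand accounts for the size or direction of this step.

A single step cannot separate the contribution of the carbonyl from that of the hydroxyl within the carboxy group, nor show whether the lower number belongs to carboxy alone or extends to other groups at this place. A methyl ester, a primary amide or an amine at the same position would test this, since the ester keeps the carbonyl without the acid hydrogen, while the amide and the amine each keep a hydrogen-bond donor.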